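The source may hold more compounds than are shown below. What is called first, only, known or untested is meant among the compounds shown, and "the series" means these compounds.

Measured in a functional assay on A549 cells (Homo sapiens) for cytotoxicity, read by MTT assay, with a stated time of 72 h (a higher number here means a weaker inhibitor, a lower number a stronger inhibitor), all values being assay limits:
Compound 1 `C=C(C)[C@@H]1CC[C@](C)(O)[C@H]1/C=C/C(C)=C/[C@@H]1C[C@@]23[C@H](OCCC[C@@H]2/C(=C(/C)C=O)CC[C@]3(C)O)O1`: > 10000 nM
Compound 2 `C=C(C)[C@H]1CC[C@@](C)(O)[C@@H]1/C=C/C(C)=C/[C@@H]1C[C@@]23[C@H](OCCC[C@@H]2/C(=C(/C)C=O)CC[C@]3(C)O)O1`: > 10000 nM
Compound 3 `C=C(C)[C@@H]1CC[C@](C)(O)[C@H]1/C=C/C(C)=C/[C@@H]1C[C@@]2([C@H](OC)O1)[C@H](CCCO)/C(=C(\C)C=O)CC[C@]2(C)O`: > 10000 nM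

Compound 3 gives > 10000 nM in this assay, and this is a limit, not a number. The whole set is bounded by the limit of > 10000 nM in this assay, at which 3 of the 3 values shown sit, so compound 3 has no readable rank among the three.

Compound 4 `C=C(C)[C@H]1CC[C@@](C)(O)[C@@H]1/C=C/C(C)=C/[C@@H]1C[C@@]2([C@H](OC)O1)[C@H](CCCO)/C(=C(\C)C=O)CC[C@]2(C)O` is the next compound to be tested in this series. Its relation to compound 3 is as follows: the two compounds have the same atoms and bonds and differ only in configuration as drawn: 3 of 11 stereo elements differ; a stereocentre at a saturated ring carbon is drawn R in compound 3 and S in compound 4; a stereocentre at a saturated ring carbon is drawn S in compound 3 and R in compound 4; a stereocentre at a saturated ring carbon is drawn S in compound 3 and R in compound 4.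

Among the compounds with values here, the one measured step that bears on this change is a step that the two limits leave unreadable from compound 1 to compound 2. That pair offers a comparable case, given (the fact that compounds 1 and 2 differ only in the configuration as drawn). Compound 2 gives > 10000 nM, again a limit. This step therefore supplies no size to carry over, and no step beyond the scatter is expected in this assay, in either direction.

The expected step is a step that the limit leaves unreadable from compound 3 to compound 4. Compound 4 is estimated at 15000 nM, with an expected range of 7000 nM to 40000 nM, and a report as a limit alone is the likeliest outcome.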

Compound 4, half-maximal inhibitory concentration: > 10000 nM
Compound 4 gave a limit, no number; the forecaster's own chance of this, stated with the estimate: 90%; the middle value is on the limit's open side.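

In this assay compound 4 gives > 10000 nM, which is a limit and not a number. Within the data shown here, no step can therefore be read between compound 3 and compound 4. The compounds shown leave open whether configuration affects this cytotoxicity at all, since none of the four has a measured number.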